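The compounds below may be only part of what the source reports. "The series", "measured", "known", "first", "only" and "open" are said of these compounds alone.

Compound 1, `CC(C)Oc1ccc(C(O)(c2ccc(C(F)(F)F)cc2)c2cccnc2)cc1`, is one of three analogues sharing a core that is examined in an ADME assay on L6 cells (Rattus norvegicus) for cytotoxicity, read by resazurin assay, with a stated time of 72 h; a lower number here means a stronger inhibitor, a higher number a weaker inhibitor. In this assay compound 1 gives 47600 nM. Compound 2, `OC(c1ccc(Cl)cc1)(c1cccnc1)c1ccc(C(F)(F)F)cc1F`, gives 57400 nM in this assay, and compound 3, `CC(C)Oc1ccc(C(O)(c2ccc(Cl)cc2)c2cccnc2)c(F)c1`, gives 58200 nM. All three numbers lie within the scatter of one another, so the data do not separate these compounds in this assay. The difference between the cores of compound 1 and compound 2 is not broken down here.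

One structural change is seen twice among these compounds. From compound 2 to compound 3 it is isopropoxy in place of trifluoromethyl on an aromatic carbon and the measured step is a 1.0-fold higher number from compound 2 to compound 3 (0.01 log units; within the scatter). The same kind of change leads from compound 1 to the unmeasured compound 4, `CC(C)Oc1ccc(C(O)(c2ccc(OC(C)C)cc2)c2cccnc2)cc1`, namely (isopropoxy in place of trifluoromethyl on an aromatic carbon); the surroundings differ in that the place in compound 2 is meta to a fluoro group (1 heavy atom) and in compound 1 it is not.

Because the step of a 1.0-fold higher number from compound 2 to compound 3 (0.01 log units; within the scatter) is within the scatter, compound 4 is expected to sit close to compound 1 in this assay, with an estimated step of a 1.1-fold higher number from compound 1 to compound 4 (0.02 log units; within the scatter). The value of compound 4 is estimated at 50000 nM, expected to fall between 25000 nM and 100000 nM.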

Compound 4, half-maximal inhibitory concentration: 61400 nM
Estimate against measurement, compound 4: 1.2-fold (0.09 log units) below; the measured number falls inside the stated range.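

In this assay, isopropoxy in place of trifluoromethyl on an aromatic carbon, para to a large group, gives a 1.3-fold higher number from compound 1 to compound 4 (0.11 log units; within the scatter). Set beside the earlier case, the change reads alike on both cores: the same change on two cores in this assay, a 1.0-fold higher number (0.01 log units; within the scatter) from compound 2 to compound 3 and a 1.3-fold higher number (0.11 log units; within the scatter) from compound 1 to compound 4, 1.3-fold (0.10 log units) apart, within the scatter of two such steps. This shows that in these two pairs the swap leaves the number within the scatter whichever core carries it, and that the fluoro group present in one pair and absent in the other brings no measurable difference between the steps; it does not show that the change is without effect in general, nor, with both steps this small, whether a step of clear size would carry over from one core to another.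

The compounds shown leave open whether any other group at this place would move the number beyond the scatter, for example an amine, a carboxylic acid or a longer ether chain. They also leave open what replacing the hydroxy group shared by all of these compounds would do in this assay, and whether the same swap would read alike on a core further removed from these.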